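Notes on the step from compound 3 to compound 4

A few compounds are considered here, and "the series" means these few. Any claim that something is new, unique, unknown or untested is made for them only; others in the source may bear on it.

Results so far in a functional assay on 1A9 cells (Homo sapiens) for cytotoxicity; a lower number here means that less compound is needed, a higher number that more compound is needed for the effect:
- compound 1 `COC1=C(C)C(=O)/C(=C(O)/C=C/c2ccc(O)cc2)C(=O)C1(C)C`: 2.9 ug/mL
- compound 2 `COC1=C(C)C(=O)/C(=C(O)/C=C/c2ccc(C)cc2)C(=O)C1(C)C`: "not determined" (no result reported)
- compound 3 `C=Cc1ccccc1/C=C/C(O)=C1/C(=O)C(C)=C(OC)C(C)(C)C1=O`: "not determined" (no result reported)

Compound 3 has no single number on this scale, and compound 2 is in the same position. Only compound 1 has a numerical result. Compound 4 `COC1=C(C)C(=O)/C(=C(O)/C=C/c2cccs2)C(=O)C1(C)C` remains unmeasured. The structural change thiophen-2-yl in place of 2-vinylphenyl on a double-bonded chain carbon bound to a double-bonded chain carbon lies on a double-bonded chain carbon bound to a double-bonded chain carbon. Among the measured compounds shown here, no measured step gives a size for this change, and compound 3 offers no starting number. Relative to compound 1 at 2.9 ug/mL as the sole anchor, no shift beyond the usual scatter in this assay is expected in either direction. For compound 4 the estimated value is 3 ug/mL with an expected range of 1 ug/mL to 9 ug/mL as a working figure.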

Compound 4, concentration for half-maximal effect: 4 ug/mL
Estimate against measurement, compound 4: 1.3-fold (0.12 log units) below, within the range that was stated.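

In this assay, among the compounds shown here, thiophen-2-yl in place of 4-hydroxyphenyl on a double-bonded chain carbon bound to a double-bonded chain carbon gives a 1.4-fold higher number from compound 1 to compound 4 (0.14 log units; within the scatter), the first readable step: at this place, the five-membered sulfur-containing ring and the six-membered carbon ring do not separate. Steps involving compound 2 or compound 3 cannot be read. Nothing available explains this result.

Still open, going by these compounds, is whether an amine or a carboxylic acid at this place would move the number beyond the scatter. On these data alone, a longer chain carrying thiophen-2-yl is equally open.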